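The source may hold more compounds than are shown below. What is called first, only, known or untested is meant among the compounds shown, and "the series" means these compounds.

Measured so far in a functional assay on cells for positive allosteric modulation of G-protein coupled receptor 68 (Homo sapiens), read by a luciferase reporter and cAMP accumulation, with a stated time of 30 min, at pH 6.8 and pH 8.3, in the presence of a further agent that is not named here; on this read-out lower numbers stand for lower potency and higher numbers for higher potency (the scale is a negative logarithm):
compound 1 `NCc1ccccc1-c1nc(N)nc(NCc2ccccc2)n1`: 3.86
compound 2 `Nc1nc(NCc2ccccc2)nc(-c2cccc(CO)c2)n1`: "not active" (no number reported)
compound 3 `Nc1nc(NCc2ccccc2F)nc(-c2ccccc2CO)n1`: 4.27

Compound 3 holds the higher of the two numbers; compound 1 sits lower by a gap beyond the usual scatter. Compound 2 returned no number in this assay, so it cannot be placed on the scale.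

Compound 4 `Nc1nc(NCCCc2ccccc2)nc(-c2ccccc2CO)n1` has not been measured. Set against compound 3, the change is phenethyl in place of 2-fluorophenyl on a saturated chain carbon bound to a nitrogen on an aromatic ring. Among the compounds with values here, no measured pair here differs in one place only, so the data give no direct reading of how this change acts. In this assay the step is expected to be a number 0.27 log units lower from compound 3 to compound 4 (within the scatter), a small decrease that barely clears the scatter, if at all. Compound 4 is therefore expected at 4, with a range from 3.5 to 4.5.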

Compound 4, negative logarithm of the antagonist equilibrium constant: 5.22
Estimate against measurement, compound 4: 1.22 log units below; measured number above the stated range.
By their numbers in this assay, from the lowest: compound 1; then compound 3; then compound 4.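

In this assay, the step of a number 0.95 log units higher from compound 3 to compound 4 (beyond the scatter) comes with phenethyl in place of 2-fluorophenyl on a saturated chain carbon bound to a nitrogen on an aromatic ring. Within the data shown here, this is the first one-place comparison, and it shows that this position accepts phenethyl with a gain beyond the scatter. No measured evidence bears on why the number moves this way.

The change removes the fluorine and alters the carbon count together, and the two cannot be separated here. From the compounds shown here alone, how a longer chain or an amine would read in place of phenethyl remains open.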